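Methyl on the phenoxy ring: a small change weighed

A few compounds are considered here, and "the series" means these few. Any claim that something is new, unique, unknown or untested is made for them only; others in the source may bear on it.

The three measured compounds share one large core and differ only in the aryl group on an oxygen on a saturated carbon. Compound 1 `CC[C@@H]1/C=C(\C)C[C@H](C)C[C@H](OC)[C@H]2O[C@@](O)(C(=O)C(=O)N3CCCC[C@H]3C(=O)O[C@H](/C(C)=C/[C@@H]3CC[C@@H](Oc4ccc(C(F)(F)F)cc4)[C@H](OC)C3)[C@H](C)[C@@H](O)CC1=O)[C@H](C)C[C@@H]2OC` carries 4-(trifluoromethyl)phenyl there and gives 35.8 nM in a functional assay on cells for inhibition, with Murine T-cell line (Mus musculus) as the target; on this read-out higher numbers stand for weaker inhibition and lower numbers for stronger inhibition. Compound 2 `CC[C@@H]1/C=C(\C)C[C@H](C)C[C@H](OC)[C@H]2O[C@@](O)(C(=O)C(=O)N3CCCC[C@H]3C(=O)O[C@H](/C(C)=C/[C@@H]3CC[C@@H](Oc4cccc(C)c4)[C@H](OC)C3)[C@H](C)[C@@H](O)CC1=O)[C@H](C)C[C@@H]2OC` carries 3-methylphenyl and gives 5.4 nM. For the measured compounds named here, compound 3 `CC[C@@H]1/C=C(\C)C[C@H](C)C[C@H](OC)[C@H]2O[C@@](O)(C(=O)C(=O)N3CCCC[C@H]3C(=O)O[C@H](/C(C)=C/[C@@H]3CC[C@@H](Oc4ccccc4)[C@H](OC)C3)[C@H](C)[C@@H](O)CC1=O)[C@H](C)C[C@@H]2OC` carries plain phenyl and gives 5.4 nM, level with compound 2 and together with it the lowest of the three numbers; the only step that is beyond the scatter is a 6.6-fold lower number from compound 1 to compound 3 (0.82 log units; beyond the scatter).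

Compound 4 `CC[C@@H]1/C=C(\C)C[C@H](C)C[C@H](OC)[C@H]2O[C@@](O)(C(=O)C(=O)N3CCCC[C@H]3C(=O)O[C@H](/C(C)=C/[C@@H]3CC[C@@H](Oc4ccc(C)cc4)[C@H](OC)C3)[C@H](C)[C@@H](O)CC1=O)[C@H](C)C[C@@H]2OC` is compound 3 with one more carbon: methyl in place of hydrogen on an aromatic carbon.

Going by the values given here, two measured steps bear on this. The step of no change at the digits printed from compound 2 to compound 3 (within the scatter) shows that a methyl on an aromatic carbon of this ring can come and go without a visible effect. The step of a 6.6-fold lower number from compound 1 to compound 3 (0.82 log units; beyond the scatter) shows that a trifluoromethyl on an aromatic carbon of the same ring does cost potency, though the entering group here is a methyl, not a trifluoromethyl. Because no change at the digits printed from compound 2 to compound 3 (within the scatter) was flat, compound 4 is expected to land close to compound 3, with at most a slight rise: the estimated step is a 1.4-fold higher number from compound 3 to compound 4 (0.14 log units; within the scatter). For compound 4 the estimate in this assay is 7.5 nM, between 3 nM and 20 nM.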

Compound 4, half-maximal inhibitory concentration: 2.7 nM
Compound 4: the middle estimate sits 2.8-fold (0.44 log units) above what was measured; the measured number lies below the stated range.
By their numbers in this assay, from the lowest: compounds 4, 2 and 3 (each within the scatter of the next); then compound 1.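

In this assay, a methyl para to a large group on the phenoxy ring makes no difference that can be told from scatter: the step is a 2.0-fold lower number from compound 3 to compound 4 (0.30 log units; within the scatter), and shifting the methyl from the 3-methylphenyl group to the 4-methylphenyl group gives a 2.0-fold lower number from compound 2 to compound 4 (0.30 log units; within the scatter), so hydrogen and both methyl placements cannot be separated on this read-out. The picture changes with the third group at this same position, where methyl in place of trifluoromethyl gives a 13-fold lower number from compound 1 to compound 4 (1.12 log units; beyond the scatter), the largest step in the series, so the higher number of compound 1 goes with trifluoromethyl specifically and not with simply having a group at this place. The data shown offer no measurement that could explain this difference between methyl and trifluoromethyl.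

Going by these compounds, with only hydrogen, methyl and trifluoromethyl to compare at this position, it remains open whether a group such as ethyl, methoxy or chlorine would read like methyl or like trifluoromethyl. On these data alone, how far the position stays flat is also open for a longer chain, an amine or a carboxylic acid placed there.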